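Rearranging the ester chain of compound 3

A few compounds are considered here, and "the series" means these few. Any claim that something is new, unique, unknown or untested is made for them only; others in the source may bear on it.

Three compounds have been measured:
compound 1 `CCOC(=O)C(C)Oc1ccc(NC(=O)CSc2ccc3ccccc3c2)cc1` with 35%;
compound 2 `CCOC(=O)C(C)Oc1ccc(NC(=O)COc2ccccc2C(C)CC)cc1` with 25%;
compound 3 `CCOC(=O)CCCOc1ccc(NC(=O)COc2ccc3ccccc3c2)cc1` with 29%.

These numbers come from a functional assay on microsomes for inhibition, read by spectrophotometry, tested at 200 ug/mL; a lower number here means less inhibition, a higher number more inhibition at the concentration tested (going by the name of the read-out). In this assay compound 3 gives 29%, a number that lies between those of compound 2 and compound 1, and both gaps are within the usual scatter of repeated measurements, so the three compounds cannot be told apart on these numbers alone. Among the measured compounds shown here, no two of the measured compounds differ in only one place, so no single step has yet been characterised.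

Compound 4 `CCOC(=O)C(C)(C)Oc1ccc(NC(=O)COc2ccc3ccccc3c2)cc1` has not been measured in this assay. It differs from compound 3 in one place: 1-(ethoxycarbonyl)-1-methylethyl in place of 3-(ethoxycarbonyl)propyl on an oxygen on an aromatic ring. The two have the same atoms, joined differently; the group that leaves and the group that enters each carry the same count of carbon and oxygen atoms and of hydrogen-bond acceptors.

For the measured compounds named here, with no measured step to lean on, the expected step of a number 1 percentage points higher from compound 3 to compound 4 (within the scatter) in this assay is none beyond the scatter. Compound 4 is therefore expected to give about 30%, with a range from 18% to 42%.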

Compound 4, a percentage reported as inhibition, at one concentration (the size of the read-out at that concentration, not a potency): 22%
Compound 4: middle estimate off by 8 percentage points, on the high side; the measured number falls inside the stated range.
By their numbers in this assay, from the lowest: compounds 4, 2, 3 and 1 (each within the scatter of the next, the first and the last beyond it).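

In this assay, swapping 3-(ethoxycarbonyl)propyl for 1-(ethoxycarbonyl)-1-methylethyl on an oxygen on an aromatic ring gives a number 7 percentage points lower from compound 3 to compound 4 (within the scatter). Among the compounds shown here, this is the first step between two compounds that differ in only one place, and it shows that rearranging these same atoms into a different chain, with the counts of atoms and hydrogen-bond acceptors unchanged, makes no difference that can be told from repeat-measurement noise. No measurement shown here bears on this step or offers an explanation for it.

As far as these compounds go, it remains open whether a carboxylic acid in place of the ethyl ester, or an amine on this oxygen, would move the number beyond the scatter. From the compounds shown here alone, it is also open whether a longer chain at this place would do so.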